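Extending compound 3 with a phenyl group: a platelet assay outlook

The compounds below may be only part of what the source reports. "The series", "measured", "known", "first", "only" and "open" are said of these compounds alone.

Measured compounds:
compound 1, `CCCCCCOc1ccc(NC(=O)C2CCCNC2)cc1`, 43000 nM
compound 2, `CCCCCCOc1cccc(NC(=O)C2CCCNC2)c1`, "not determined" (no result reported)
compound 3, `O=C(Nc1cccc(OCc2ccccc2)c1)C1CCCNC1`, "not determined" (no result reported)

In a functional assay on a cell-free system (Platelet, plasma, Homo sapiens) for inhibition (a lower number here means a stronger inhibitor, a higher number a weaker inhibitor), compound 1 gives 43000 nM. For compound 2 the result in this assay is "not determined" (no result reported). Going by the values given here, compound 3 likewise has no single number in this assay, its entry being "not determined" (no result reported), so compound 3 stands without a value, and no step between measured compounds is available. Compound 4, `O=C(Nc1cccc(OCc2ccc(-c3ccccc3)cc2)c1)C1CCCNC1`, differs from compound 3 by phenyl in place of hydrogen on an aromatic carbon. Among the compounds with values here, with no measured step to lean on, the size of the step in this assay from compound 3 to compound 4 cannot be derived from the data; the only anchor is the weak value of compound 1 in this assay, 43000 nM. Compound 4 is therefore estimated at 20000 nM, within 3000 nM to 120000 nM.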

Compound 4, half-maximal inhibitory concentration: 87000 nM
The estimate for compound 4 lay 4.4-fold (0.64 log units) below the measured number; low and high end bracket the measured number.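

Going by these compounds alone, no step from compound 3 to compound 4 can be read from the value of compound 4, 87000 nM, in this assay. No supporting data bear on this result. The compounds shown leave open what the added phenyl changes in this assay.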